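Adding chloro to a compound sitting at the assay limit

This account rests on a few compounds, and the source may have more. Where it says the series, first, only, none or still open, it means among the compounds named here.

- Compound 1 `CN1C(=O)C(O)(Cc2nnn[nH]2)c2ccccc21`: 36800 nM
- Compound 2 `CCN1C(=O)C(O)(Cc2nnn[nH]2)c2ccccc21`: > 100000 nM (a limit, not a number)
- Compound 3 `O=C1N(Cc2ccc(Br)cc2)c2ccc(F)cc2C1(O)Cc1nnn[nH]1`: 14400 nM

All three compounds were tested in a functional assay on DU-145 cells (Homo sapiens) for antiproliferative activity, read by MTT assay, with a stated time of 48 h; on this read-out lower numbers stand for stronger inhibition and higher numbers for weaker inhibition. Compound 2 stands at > 100000 nM, which is a limit of the assay and not a number. Compound 4 `CCN1C(=O)C(O)(Cc2nnn[nH]2)c2cc(Cl)ccc21` comes from compound 2 by a single change, chloro in place of hydrogen on an aromatic carbon. For the measured compounds named here, the only measured single-place step is an at least 2.7-fold higher number from compound 1 to compound 2 (0.43 log units; beyond the scatter). That step placed methyl on a saturated chain carbon, elsewhere in the molecule, so it says little about size here. Going by the values given here, for direction, the one hint is compound 3, which carries fluoro on its aromatic ring among other differences and gives 14400 nM. A modest move towards a lower number in this assay therefore seems likely, though compound 4 may also stay at the limit. The expected change is an at least 1.6-fold lower number from compound 2 to compound 4 (0.22 log units; that floor lies within the scatter). For compound 4 the estimated value is 60000 nM. The expected range for compound 4 runs from 20000 nM to 100000 nM.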

Compound 4, half-maximal inhibitory concentration: 21500 nM
Compound 4: middle estimate off by 2.8-fold (0.45 log units), on the high side, within the range that was stated.
By their numbers in this assay, from the lowest: compounds 3, 4 and 1 (each within the scatter of the next, the first and the last beyond it). At a limit, above all of these: compound 2.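

In this assay, chloro in place of hydrogen on an aromatic carbon gives an at least 4.6-fold lower number from compound 2 to compound 4 (0.66 log units; beyond the scatter), so this single added atom on the six-membered aromatic ring moves the number in the opposite direction to the earlier change on the saturated chain, an at least 2.7-fold higher number from compound 1 to compound 2 (0.43 log units; beyond the scatter). The starting point, compound 2 at > 100000 nM, is a limit and not a number. The step is therefore only a floor, and its full size cannot be read because it starts from a limit: the limit of > 100000 nM in this assay, at which 1 of the 4 values shown sits.

The compounds shown do not tell whether chloro itself matters here, or whether a bromo, a methoxy or an amine on this same carbon would do as much. They also leave open whether chloro would lower the number of compound 1 in the same way.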